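A Longer Acid-Ended Chain on the Shared Core

The source may hold more compounds than are shown below. What is called first, only, known or untested is meant among the compounds shown, and "the series" means these compounds.

Compound 3 `O=c1c(-c2ccc(O)cc2)coc2cc(OCCC3OCCCO3)ccc12` shares its core with compound 1 `O=c1c(-c2ccc(O)cc2)coc2cc(OCCCCCCBr)ccc12` and compound 2 `O=c1c(-c2ccc(O)cc2)coc2cc(OCCCCBr)ccc12`; the three differ only in the chain that hangs from an oxygen on an aromatic ring. In an assay on isolated protein (Cricetulus griseus) for inhibition of aldehyde dehydrogenase, mitochondrial (Homo sapiens) (on this read-out higher numbers stand for weaker inhibition and lower numbers for stronger inhibition), compound 1 gives 300 nM, compound 2 gives 270 nM, and compound 3 gives 400 nM. Compound 3 holds the highest of the three numbers, yet every gap is within the scatter: a 1.3-fold higher number from compound 1 to compound 3 (0.12 log units; within the scatter) and a 1.5-fold higher number from compound 2 to compound 3 (0.17 log units; within the scatter), while a 1.1-fold lower number from compound 1 to compound 2 (0.05 log units; within the scatter). On these numbers the three compounds cannot be told apart.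

Compound 4 `O=C(O)CCCCCCCCCOc1ccc2c(=O)c(-c3ccc(O)cc3)coc2c1` has not yet been measured. The change from compound 3 to compound 4 is a group of 10 heavy atoms (8 carbon, 2 oxygen; no ring) in place of a group of 6 heavy atoms (4 carbon, 2 oxygen; one six-membered non-aromatic ring with 2 hetero atoms), on a saturated chain carbon, two bonds along the chain from an oxygen on an aromatic ring. The two measured steps at this same place, a 1.3-fold higher number from compound 1 to compound 3 (0.12 log units; within the scatter) and a 1.5-fold higher number from compound 2 to compound 3 (0.17 log units; within the scatter), both stayed within the scatter, so the chain at this position has so far left the read-out where it was. Among the measured compounds shown here, the new chain is the longest of the set, and no measured compound carries the 7-carboxyheptyl group, so the range is kept wide. The expected step is no change at the digits printed from compound 3 to compound 4 (within the scatter), no further than the scatter. Compound 4 is estimated at 400 nM, with a range from 150 nM to 1100 nM.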

Compound 4, half-maximal inhibitory concentration: 4 nM
Beside the measured number, compound 4's estimate is 100-fold (2.00 log units) above it, and the stated range ends above it.
By their numbers in this assay, from the lowest: compound 4; then compounds 2, 1 and 3 (each within the scatter of the next).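

Among compounds 1, 2 and 3, neither the bromo-ended chains nor the chain ending in a six-membered ring with two oxygens moved the read-out beyond the scatter, so this position could have seemed to matter little. Compound 4 changes that picture: in this assay the 7-carboxyheptyl chain gives a 100-fold lower number from compound 3 to compound 4 (2.00 log units; beyond the scatter) against the ring-ended chain, and both a 68-fold lower number from compound 2 to compound 4 (1.83 log units; beyond the scatter) and a 75-fold lower number from compound 1 to compound 4 (1.88 log units; beyond the scatter) against the bromo-ended chains. Among the compounds shown here, the chain on this oxygen can therefore shift the number far beyond the scatter, here towards stronger inhibition, which no step among the earlier compounds showed.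

Compound 4 has both the only chain ending in a carboxylic acid and the longest chain in the set, so these compounds cannot separate the acid end from the chain length; a plain alkyl chain of the same length, a shorter acid-ended chain, or the methyl ester or primary amide of this chain would be needed to tell them apart. Nothing available here explains why this chain gives so large a step.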